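A few compounds are considered here, and "the series" means these few. Any claim that something is new, unique, unknown or untested is made for them only; others in the source may bear on it.

Of the compounds shown here, three sharing one core have been measured in a functional assay on cells for inhibition of leukotriene B4 receptor 1 (Homo sapiens); a lower number here means a stronger inhibitor, a higher number a weaker inhibitor. Compound 1, an ester, `COC(=O)CCCCCOc1cc(-c2ccccc2)cc(-c2ccccc2)n1`, gives in this assay 1000 nM. Compound 2, a shorter acid, `O=C(O)CCCCOc1cc(-c2ccccc2)cc(-c2ccccc2)n1`, gives in this assay 20000 nM. Compound 3, a longer acid, `O=C(O)CCCCCCOc1cc(-c2ccccc2)cc(-c2ccccc2)n1`, gives in this assay 2500 nM; it stands second highest of the three numbers, nearest to compound 1 and furthest from compound 2.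

Compound 4, `CC(C)(CCCCCCOc1cc(-c2ccccc2)cc(-c2ccccc2)n1)C(=O)O`, is not yet measured. Its change from compound 3 is 1-carboxy-1-methylethyl in place of carboxy on a saturated chain carbon, six bonds along the chain from an oxygen on an aromatic ring.

For the measured compounds named here, no measured step alters the carbon framework around the carboxy in this way, so the guidance is indirect. The step of an 8.0-fold lower number from compound 2 to compound 3 (0.90 log units; beyond the scatter) shows that moving the carboxy further out along the chain lowered the number, and the step of a 2.5-fold higher number from compound 1 to compound 3 (0.40 log units; beyond the scatter) shows that the longer acid sits only modestly behind the ester. Since compound 4 again places the carboxy one carbon further from the ring, though now with two methyls on that carbon, a modest lowering is expected, with wide uncertainty. For compound 4 the expected step is a 1.7-fold lower number from compound 3 to compound 4 (0.22 log units; within the scatter), giving an estimate of 1500 nM, within a range from 400 nM to 6000 nM.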

Compound 4, half-maximal inhibitory concentration: 100 nM
Beside the measured number, compound 4's estimate is 15-fold (1.18 log units) above it; the whole stated range lies above it.
By their numbers in this assay, from the lowest: compound 4; then compound 1; then compound 3; then compound 2.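

In this assay, for the compounds shown here, the swap of carboxy for 1-carboxy-1-methylethyl at the chain end gives a 25-fold lower number from compound 3 to compound 4 (1.40 log units; beyond the scatter), so the carbons around the acid matter a great deal, which the earlier compounds, differing only in chain length or in acid versus ester, could not show. An acid can also outdo the ester: compound 3 had stayed behind compound 1, whereas the new branched acid gives a 10-fold lower number from compound 1 to compound 4 (1.00 log units; beyond the scatter). Against the short acid the gain reaches a 200-fold lower number from compound 2 to compound 4 (2.30 log units; beyond the scatter), and compound 4 now has the lowest number of the set, with its steps to all three others beyond the usual scatter, so this end of the chain is a place where a small change can shift the number strongly.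

No measured information on the compounds explains this gain. On these data alone, it remains open how much comes from the methyl groups and how much from the added chain carbon, a question that a longer unbranched carboxylic acid or a cyclopropyl ring in place of the methyl groups would help to answer.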